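Compound 2 to compound 4: benzoylating the aminoethyl chain

The compounds below may be only part of what the source reports. "The series", "measured", "known", "first", "only" and "open" are said of these compounds alone.

Values in a functional assay on MDA-MB-231 cells (Homo sapiens) for cytotoxicity, read by MTT assay, with a stated time of 96 h; a lower number here means a stronger inhibitor, a higher number a weaker inhibitor:
- compound 1 `CC[C@H](N)C(=O)N[C@@H]1C(=O)N2[C@@H](CC[C@@H]1CCN)CC[C@H]2C(=O)NC(c1ccccc1)c1ccccc1` gives 12900 nM
- compound 2 `CC[C@H](NC)C(=O)N[C@@H]1C(=O)N2[C@@H](CC[C@@H]1CCN)CC[C@H]2C(=O)NC(c1ccccc1)c1ccccc1` gives 2300 nM
- compound 3 `CC[C@H](N)C(=O)N[C@@H]1C(=O)N2[C@@H](CC[C@@H]1CCO)CC[C@H]2C(=O)NC(c1ccccc1)c1ccccc1` gives 1800 nM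

Compound 2, at 2300 nM, is second highest of the three numbers. It lies within the scatter of compound 3 and well under compound 1.

Compound 4 `CC[C@H](NC)C(=O)N[C@@H]1C(=O)N2[C@@H](CC[C@@H]1CCNC(=O)c1ccccc1)CC[C@H]2C(=O)NC(c1ccccc1)c1ccccc1` carries benzoyl in place of hydrogen on an amine nitrogen, turning 2-aminoethyl into 2-benzamidoethyl (benzoyl in place of hydrogen on an amine nitrogen). Within the data shown here, no measured compound has an acyl group on this nitrogen, so the precedents are indirect.

The nearest one is the change at the same chain end, hydroxy in place of amino, a 7.2-fold lower number from compound 1 to compound 3 (0.86 log units; beyond the scatter). That step replaced the amino group rather than extending it, so it is only a loose guide. The other measured step, methyl in place of hydrogen on an amine nitrogen, a 5.6-fold lower number from compound 1 to compound 2 (0.75 log units; beyond the scatter), concerns the other amine, and its methyl is already present in compound 2. Whether the two steps add up has not been measured.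

A modest move towards a lower number is therefore expected, with wide uncertainty. The expected size of the step is a 2.9-fold lower number from compound 2 to compound 4 (0.46 log units; beyond the scatter). For compound 4 the estimated value is 800 nM, with an expected range from 150 nM to 4000 nM.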

Compound 4, half-maximal inhibitory concentration: 210 nM
Beside the measured number, compound 4's estimate is 3.8-fold (0.58 log units) above it; low and high end bracket the measured number.
By their numbers in this assay, from the lowest: compound 4; then compounds 3 and 2 (each within the scatter of the next); then compound 1.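

In this assay, the amine nitrogen of the 2-aminoethyl chain accepts benzoyl, with its 8 heavy atoms and six-membered aromatic ring, and the step of an 11-fold lower number from compound 2 to compound 4 (1.04 log units; beyond the scatter) is large. Among these compounds, until now, the only information at this chain end was the replacement of amino by hydroxy, a 7.2-fold lower number from compound 1 to compound 3 (0.86 log units; beyond the scatter), a modest step that removed the nitrogen and was taken with hydrogen rather than methyl on the other amine; compound 4 shows that the nitrogen can stay and that much larger substitution on it goes with a lower number. The two steps start from different compounds, so their sizes give no ranking of hydroxy against benzamido, and nothing available explains the size of the benzoyl step.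

Still open, from the compounds shown here alone, is which part of the 2-benzamidoethyl group carries the step: acetyl would keep the carbonyl without the aromatic ring, benzyl would keep the aromatic ring without the carbonyl, and a longer chain would test the distance from the core. Going by these compounds, it is also open whether benzoyl gives a similar step on compound 1, where the other amine carries hydrogen rather than methyl.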